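Compound 4: a new group on the carbonyl carbon

A few compounds are considered here, and "the series" means these few. Any claim that something is new, unique, unknown or untested is made for them only; others in the source may bear on it.

In an ADME assay on Vero cells (Chlorocebus sabaeus) for cytotoxicity, read by resazurin assay, with a stated time of 72 h (a higher number here means a weaker inhibitor, a lower number a stronger inhibitor), compound 1 `Cc1ccc(C(=O)CCN2CCN(c3ccc(F)cc3)CC2)cc1` gives 55400 nM and holds the lowest number of the three measured, with compound 2 `Cc1ccc(C(=O)CCN2CCN(c3ccc(Cl)cc3)CC2)cc1` at 184000 nM and compound 3 `Cc1ccc(C(=O)CCN2CCN(c3ccc([N+](=O)[O-])cc3)CC2)cc1` at 235000 nM in the same series. Compound 4 `O=C(CCN1CCN(c2ccc(F)cc2)CC1)c1ccc(Cl)c(F)c1` departs from compound 1 in one place, where 4-chloro-3-fluorophenyl in place of 4-methylphenyl on a carbonyl carbon stands as the change on a carbonyl carbon.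

The measured steps all lie elsewhere, on an aromatic carbon, with the 4-methylphenyl untouched. Chloro in place of fluoro gives a 3.3-fold higher number from compound 1 to compound 2 (0.52 log units; beyond the scatter) as a modest move, nitro in place of fluoro gives a 4.2-fold higher number from compound 1 to compound 3 (0.63 log units; beyond the scatter) as another, and nitro in place of chloro gives a 1.3-fold higher number from compound 2 to compound 3 (0.11 log units; within the scatter) inside the scatter. Compound 4 keeps the fluoro of compound 1, so none of these steps measures the new change directly. They show only how far a single substitution has moved this series.

The measured steps give no direction for a change on the carbonyl carbon. Compound 1 at 55400 nM therefore stays the anchor, and no step beyond the scatter is expected, though a modest one either way remains possible. The expected step is a 1.1-fold lower number from compound 1 to compound 4 (0.04 log units; within the scatter) on this reading. In this assay compound 4 is estimated at 50000 nM with an expected range from 18000 nM to 140000 nM as its bounds.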

Compound 4, half-maximal inhibitory concentration: 105000 nM
For compound 4 the middle estimate is 2.1-fold (0.32 log units) below the measured one, within the range that was stated.
By their numbers in this assay, from the lowest: compounds 1, 4, 2 and 3 (each within the scatter of the next, the first and the last beyond it).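

In this assay, among these compounds, the one exchange on the carbonyl carbon, 4-chloro-3-fluorophenyl in place of 4-methylphenyl, gives a 1.9-fold higher number from compound 1 to compound 4 (0.28 log units; within the scatter). The position therefore accepts this exchange of one six-membered aromatic ring for another, with its two halogens and one more heavy atom, without a step beyond the scatter, unlike the changes on an aromatic carbon that give a 3.3-fold higher number from compound 1 to compound 2 (0.52 log units; beyond the scatter) and a 4.2-fold higher number from compound 1 to compound 3 (0.63 log units; beyond the scatter). No measurement on these compounds accounts for this result.

A single exchange leaves the contributions of the chloro and the fluoro of the entering group inseparable, and it leaves open whether the same exchange would stay within the scatter on the chloro and nitro compounds, compound 2 and compound 3. Also open, as far as these compounds go, is how the carbonyl carbon responds to a group of another kind, such as a cyclohexyl ring, a pyridine ring, or a phenyl ring carrying an amine or a carboxylic acid.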